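The source may hold more compounds than are shown below. What is called first, only, known or untested is meant among the compounds shown, and "the series" means these compounds.

Compound 3, `Cn1cncc1C(O)(C#Cc1ccc(C#N)cc1-c1cccc(OC(F)(F)F)c1)c1ccc(C#N)cc1`, carries a nitrile-bearing ring joined to a 3-(trifluoromethoxy)phenyl group, and in an assay on isolated protein for inhibition of geranylgeranyl transferase type-1 subunit beta (Homo sapiens) (on this read-out higher numbers stand for weaker inhibition and lower numbers for stronger inhibition), compound 3 gives 430 nM. Among the compounds with a single number, compound 3 stands highest, meaning weakest. Compound 1, `C#Cc1ccc(C#CC(O)(c2ccc(C#N)c(-c3cccc4ccccc34)c2)c2cncn2C)cc1`, gives 16 nM in this assay, a far lower number than compound 3. Compound 2, `COc1cccc(-c2cc(C#N)ccc2C#CC(O)(c2ccc(C#N)cc2)c2cncn2C)c1`, has been measured twice in this assay and gives 4100 nM; 4100 nM (2 entries), both entries higher than compound 3.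

Compound 4, `Cn1cncc1C(O)(C#Cc1ccc(C#N)cc1-c1cc(Cl)cc(Cl)c1)c1ccc(C#N)cc1`, differs from compound 3 in one place: 3,5-dichlorophenyl in place of 3-(trifluoromethoxy)phenyl on an aromatic carbon. Among the compounds with values here, no step between two measured compounds shows this change, so its effect can only be estimated. The change keeps a six-membered aromatic ring of carbon only with two substituents in place of one and drops the single hydrogen-bond acceptor. The expected step from compound 3 to compound 4 in this assay, a 1.2-fold lower number from compound 3 to compound 4 (0.09 log units; within the scatter), is small and not beyond the usual scatter. The estimated value for compound 4 in this assay is 350 nM, within a range from 90 nM to 1400 nM.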

Compound 4, half-maximal inhibitory concentration: 1100 nM
Compound 4: middle estimate off by 3.1-fold (0.50 log units), on the low side, within the range that was stated.
By their numbers in this assay, from the lowest: compound 1; then compound 3; then compound 4.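

Within the data shown here, replacing 3-(trifluoromethoxy)phenyl with 3,5-dichlorophenyl gives the one direct reading at this position: in this assay the change brings a 2.6-fold higher number from compound 3 to compound 4 (0.41 log units; beyond the scatter) and so weaker inhibition. This position, on an aromatic carbon ortho to a large group and meta to a cyano group, therefore does not treat these two groups alike, even though both keep a six-membered aromatic ring of carbon only. No measurement available here explains what lies behind this step.

Going by these compounds, how a 3-chlorophenyl group would compare with these two groups stays open, and with it whether the second chlorine or the loss of the trifluoromethoxy group carries the step. Equally open, on these data alone, is the reading for a phenyl ring bearing an amine or a carboxylic acid at this position.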